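Adding a Second Methyl to the Aryl Ring

A few compounds are considered here, and "the series" means these few. Any claim that something is new, unique, unknown or untested is made for them only; others in the source may bear on it.

Measured compounds:
- Compound 1 `Cc1ccc(C(=O)/C=C/c2ccc3c(c2)B(O)OC3)cc1`: 10500 nM
- Compound 2 `Cc1cccc(C(=O)/C=C/c2ccc3c(c2)B(O)OC3)c1`: 6700 nM

In a functional assay on HCT-116 cells (Homo sapiens) for cytotoxicity, read by MTT assay, with a stated time of 48 h (on this read-out lower numbers stand for stronger inhibition and higher numbers for weaker inhibition), compound 1 gives 10500 nM, while compound 2 gives 6700 nM. Within the data shown here, the only step between them, a 1.6-fold lower number from compound 1 to compound 2 (0.20 log units; within the scatter), is the move of the methyl group on the carbonyl-bound ring, and it stays within the scatter, so the two numbers cannot be ordered. Among the measured compounds shown here, compound 2 holds the lower of the two numbers, with compound 1 as its only neighbour.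

Compound 3 `Cc1ccc(C(=O)/C=C/c2ccc3c(c2)B(O)OC3)cc1C` has not yet been measured. It differs from compound 2 by methyl in place of hydrogen on an aromatic carbon, placed ortho to a methyl group and para to a large group; the ring of compound 3 thus carries both the methyl of compound 1 and that of compound 2. For the measured compounds named here, the single relevant step, a 1.6-fold lower number from compound 1 to compound 2 (0.20 log units; within the scatter), shows that shifting one methyl around this ring changes nothing beyond the scatter. Compound 3 is therefore expected to show no step beyond the scatter in this assay, that is a 1.1-fold lower number from compound 2 to compound 3 (0.05 log units; within the scatter), and its estimated value is 6000 nM, within a range of 2500 nM to 14000 nM.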

Compound 3, half-maximal inhibitory concentration: 6100 nM
Compound 3: the middle estimate sits 1.0-fold (0.01 log units) below what was measured, within the range that was stated.
By their numbers in this assay, from the lowest: compounds 3, 2 and 1 (each within the scatter of the next).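

In this assay, methyl in place of hydrogen on an aromatic carbon, ortho to a methyl group and para to a large group, gives a 1.1-fold lower number from compound 2 to compound 3 (0.04 log units; within the scatter) on this ring, and the same kind of change gives a 1.7-fold lower number from compound 1 to compound 3 (0.24 log units; within the scatter) in the second pair. The earlier compounds shown here showed only that a single methyl could sit at either of two places on this ring with no step beyond the scatter. The new steps show that both places can be filled at once, again with no step beyond the scatter, so this read-out does not separate the ring with both methyl groups from either ring with one, and nothing at hand bears on why the added methyl leaves the number where it is.

From the compounds shown here alone, all three compounds carry only methyl on this ring, so what a methoxy group, a fluorine, an amine or a longer chain such as ethyl would do at these places stays open. Also open, going by these compounds, is whether any change on this ring can move the number beyond the scatter, as every step among compound 1, compound 2 and compound 3 lies within it.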